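Three Fluorines Rearranged: Expected Cytotoxicity of Compound 4

The source may report more compounds than this note shows. Statements on the series, on what has been measured and on what is new or still open speak of the compounds shown alone.

Three compounds have been measured in an ADME assay on MT4 cells (Homo sapiens) for cytotoxicity, read by MTT assay; a lower number here means that less compound is tolerated, a higher number that more compound is tolerated:

Compound 1, `CCOC(=O)/C(O)=C/C(=O)c1cn(Cc2c(F)ccc(F)c2F)c2cccc(OC)c12`, gives 40500 nM.
Compound 2, `COc1cccc2c1c(C(=O)/C=C(\O)C(=O)O)cn2Cc1c(F)ccc(F)c1F`, gives 49400 nM.
Compound 3, `CCOC(=O)/C(O)=C/C(=O)c1cn(Cc2c(F)cccc2F)c2cccc(OC)c12`, gives 63400 nM.

Compound 2 sits within the scatter of both other compounds: the nearest number is that of compound 1, the furthest that of compound 3, and neither gap is larger than repeated measurements of this kind usually show.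

Compound 4, `COc1cccc2c1c(C(=O)/C=C(\O)C(=O)O)cn2Cc1cc(F)c(F)c(F)c1`, has not yet been measured. It differs from compound 2 in one place: 3,4,5-trifluorophenyl in place of 2,3,6-trifluorophenyl on a saturated chain carbon bound to an aromatic nitrogen.

Among the compounds with values here, two measured steps bear on this. The step of a 1.2-fold higher number from compound 1 to compound 2 (0.09 log units; within the scatter) shows that a change at the other end of the shared core barely moves the number. The step of a 1.6-fold higher number from compound 1 to compound 3 (0.19 log units; within the scatter) is the closer analogy, since it also changes a fluorine on the same phenyl ring, and it too stays within the scatter. Nothing among these compounds points to a shift beyond the usual spread, so for compound 4 the expected step is a 1.0-fold higher number from compound 2 to compound 4 (0.01 log units; within the scatter).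

The estimate for compound 4 in this assay is therefore 50000 nM, expected to fall between 25000 nM and 100000 nM.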

Compound 4, half-maximal cytotoxic concentration: 23300 nM
For compound 4 the middle estimate is 2.1-fold (0.33 log units) above the measured one; the whole stated range lies above it.
By their numbers in this assay, from the lowest: compounds 4, 1, 2 and 3 (each within the scatter of the next, the first and the last beyond it).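

In this assay, rearranging the three fluorines on the phenyl ring, with no atom gained or lost, gives a 2.1-fold lower number from compound 2 to compound 4 (0.33 log units; beyond the scatter), a modest step but the first one here to pass beyond the scatter. Within the data shown here, this shows that, on a saturated chain carbon bound to an aromatic nitrogen, the number can respond to where the fluorines stand on the ring and not only to which atoms are present, something the one earlier step on this ring, a 1.6-fold higher number from compound 1 to compound 3 (0.19 log units; within the scatter), did not show. No measurement among these compounds explains why this rearrangement moves the number.

All the fluorine positions that differ change together in this single step, so the compounds shown cannot tell which of them accounts for it, or whether the same step would appear with the ethyl ester of compound 1 in place of the carboxylic acid of compound 2. Going by these compounds, it also stays open how a phenyl ring carrying no fluorine, or a chlorophenyl group, would behave at this place.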